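Removing the Ring Fluorine from a Weak Cytotoxic Triazolothiadiazine

The source may report more compounds than this note shows. Statements on the series, on what has been measured and on what is new or still open speak of the compounds shown alone.

The shared core carries a trimethoxyphenyl group, a five-membered ring at one side of the core and a ketone bearing a second aromatic ring. Compound 1 `COc1cc(-c2nnc3n2NC(c2ccco2)C(C(=O)c2ccccc2F)S3)cc(OC)c1OC` has a furan and a fluorine on the aromatic ring of the ketone. In a functional assay on HepG2 cells (Homo sapiens) for cytotoxicity, read by MTT assay, with a stated time of 48 h (on this read-out lower numbers stand for stronger inhibition and higher numbers for weaker inhibition), compound 1 gives > 100000 nM, which is a limit of the assay and not a measured number. Going by the values given here, compound 2 `COc1cc(-c2nnc3n2NC(c2cccs2)C(C(=O)c2ccc(F)cc2)S3)cc(OC)c1OC`, with a thiophene in place of the furan and the fluorine moved to another position, is the only other compound measured; in this assay compound 2 gives 54200 nM. Compound 3 `COc1cc(-c2nnc3n2NC(c2ccco2)C(C(=O)c2ccccc2)S3)cc(OC)c1OC` is compound 1 with hydrogen in place of fluoro on an aromatic carbon, the change counted as hydrogen in place of fluoro on an aromatic carbon; the carbon sits in the six-membered aromatic ring of carbon only, ortho to a large group.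

Among the compounds with values here, because compound 1 sits at the limit of > 100000 nM in this assay, at which 1 of the 2 values shown sits, no measured step can be drawn around it. The step from compound 1 to compound 3 is expected to be small, a number no higher from compound 1 to compound 3 (the limit leaves the size open), with no clear direction beyond the scatter. Compound 3 is therefore estimated at 100000 nM, within 40000 nM to 300000 nM.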

Compound 3, half-maximal inhibitory concentration: 90900 nM
Estimate against measurement, compound 3: 1.1-fold (0.04 log units) above; the range from low to high includes it.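

In this assay, going by these compounds alone, compound 3 gives 90900 nM, which is the first real number for a compound with the furan and a ketone ring of this kind. Compound 1 remains a limit of the assay at > 100000 nM. The change of hydrogen in place of fluoro on an aromatic carbon, ortho to a large group, can therefore be read only as an at least 1.1-fold lower number from compound 1 to compound 3 (0.04 log units; that floor lies within the scatter), and its true size remains unknown because of where compound 1 stands: the limit of > 100000 nM in this assay, at which 1 of the 3 values shown sits.

As far as these compounds go, what remains open is whether another group at this carbon, such as a chlorine atom, a methoxy group or an amine, would shift the number beyond the scatter, as a single-place comparison with compound 3 could show. Compound 2 differs from compound 3 in more than one place, so it cannot separate the effect of the thiophene from that of the fluorine on the aromatic ring of the ketone.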